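This account rests on a few compounds, and the source may have more. Where it says the series, first, only, none or still open, it means among the compounds named here.

Working notes on the series. Compound 1 `Cc1nn(-c2ccccn2)c2cc(-c3ccc(CCC(=O)O)cc3)ccc12` is the reference point; in a functional assay on cells for agonist activity at Free fatty acid receptor 1 (Mus musculus), read by FLIPR and calcium flux, with a stated time of 5 min (a higher number here means that more compound is needed for the effect, a lower number that less compound is needed), compound 1 gives 1400 nM, the lowest of the two numbers in hand. Its nearest neighbour is compound 3 `Cc1nn(-c2ccccn2)c2cc(-c3ccc(CCCC(=O)O)cc3)ccc12`, which in this assay gives 2100 nM; the step of a 1.5-fold higher number from compound 1 to compound 3 (0.18 log units; within the scatter) is within the scatter, so the two are read as equivalent. Compound 2 `Cc1nn(-c2ccccn2)c2cc(-c3ccc(CC(C)(C)C(=O)O)cc3)ccc12` reaches only a limit in this assay, > 100000 nM, recorded as the limit of > 100000 nM in this assay, at which 1 of the 3 values shown sits. The steps of an at least 71-fold higher number from compound 1 to compound 2 (1.85 log units; beyond the scatter) and an at least 47-fold lower number from compound 2 to compound 3 (1.67 log units; beyond the scatter) are the only large ones seen, and both concern the acid-bearing chain.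

Compound 4 `O=C(O)CCc1ccc(-c2ccc3cnn(-c4ccccn4)c3c2)cc1` differs from compound 1 elsewhere: hydrogen in place of methyl on an aromatic carbon. Among the compounds with values here, none of the measured steps touches this position; all three vary the chain on the phenyl ring, and the methyl on the core is held constant throughout. Within the data shown here, there is therefore no step here on which to base a shift, and the expectation for compound 4 in this assay is a change of a 1.1-fold higher number from compound 1 to compound 4 (0.03 log units; within the scatter), that is, none beyond the scatter. The estimate for compound 4 is 1500 nM, with a range of 500 nM to 5000 nM.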

Compound 4, half-maximal effective concentration: 4500 nM
Compound 4: middle estimate off by 3.0-fold (0.48 log units), on the low side; low and high end bracket the measured number.
By their numbers in this assay, from the lowest: compounds 1 and 3 (each within the scatter of the next); then compound 4. At a limit, above all of these: compound 2.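

Within the data shown here, the methyl on the aromatic carbon of the five-membered aromatic ring is the first place outside the acid-bearing chain to change, and it is not silent: in this assay, hydrogen in place of methyl gives a 3.2-fold higher number from compound 1 to compound 4 (0.51 log units; beyond the scatter). The step is modest, and compound 4 keeps a measured number rather than a limit, so activity survives the loss of this methyl while the shift still lies beyond the scatter. Nothing in hand accounts for the shift.

The compounds shown leave open whether a group larger than methyl on this carbon, such as ethyl or trifluoromethyl, or a different one, such as an amine or chlorine, would give a lower or a higher number. As far as these compounds go, the same change on the longer acid-bearing chain of compound 3 also remains open.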